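The compounds below may be only part of what the source reports. "The series", "measured", "known", "first", "only" and "open" are said of these compounds alone.

Working notes on the series.

Three compounds carry numbers in an assay on HEK293-TREx cells for antagonist activity at transient receptor potential cation channel subfamily A member 1 (Homo sapiens), read by fluorescence and calcium flux, with a stated time of 72 h; a higher number here means a weaker inhibitor, a lower number a stronger inhibitor. Compound 1 `c1ccc(Oc2ncnc3[nH]ccc23)cc1` gives 3200 nM. Compound 2 `COc1ccc(Oc2ncnc3[nH]ccc23)cc1` gives > 32000 nM, which is a limit of the assay and not a number. The measured step of an at least 10-fold lower number from compound 2 to compound 1 (1.00 log units; beyond the scatter) corresponds to the change (hydrogen in place of methoxy on an aromatic carbon). The value of compound 2 rests at the limit of > 32000 nM in this assay, at which 1 of the 3 values shown sits.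

Compound 3 `COc1cc2ccnc(Oc3ccc(F)cc3F)c2cc1OC` stands on a different core; the difference between the core of compound 3 and that of compound 2 is not broken down here. In this assay compound 3 gives 630 nM, the lowest of the two numbers, with compound 1 as the nearest number at a higher value, a gap beyond the scatter.

Compound 4 `COc1ccc2c(Oc3ccc(F)cc3F)nccc2c1` is not yet measured. Going by the values given here, the change hydrogen in place of methoxy on an aromatic carbon is the same kind of change as the one from compound 2 to compound 1, hydrogen in place of methoxy on an aromatic carbon, but the place differs: in compound 2 the methoxy is para to a large group on a ring of carbon only, while in compound 3 it sits on a six-membered aromatic ring of carbon only within a fused system of two rings, ortho to a methoxy group, meta and para to a fused ring. One measured example, at a different place, is a thin basis, so a smaller step is expected here: a 1.6-fold lower number from compound 3 to compound 4 (0.20 log units; within the scatter) for compound 4 in this assay, with wide bounds. Compound 4 is accordingly estimated at 400 nM, between 120 nM and 1500 nM.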

Compound 4, half-maximal inhibitory concentration: 1300 nM
Estimate against measurement, compound 4: 3.3-fold (0.51 log units) below, within the range that was stated.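

In this assay, hydrogen in place of methoxy on an aromatic carbon gives a 2.1-fold higher number from compound 3 to compound 4 (0.31 log units; beyond the scatter), so the change does not carry over from one core to the other with the same direction or size: the same change on two cores in this assay, an at least 10-fold lower number (1.00 log units; beyond the scatter) from compound 2 to compound 1 and a 2.1-fold higher number (0.31 log units; beyond the scatter) from compound 3 to compound 4, at least 20-fold (1.31 log units) apart, beyond the scatter of two such steps

The earlier step rests on compound 2, whose value is a limit of the assay and not a number, so only a bound on that step's size can be read: the limit of > 32000 nM in this assay, at which 1 of the 4 values shown sits.

The comparison shows that one step in this series does not predict the other, but it rests on a single pair per core, and the methoxy group leaves a different place in each pair, so the core and the place cannot be told apart as the source of the difference.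

Open, as far as these compounds go, is what would happen if the methoxy group that remains in compound 4 were replaced by hydrogen, which would show whether the step seen here holds at a second place on the same core. Also open, from the compounds shown here alone, is how a longer chain such as ethoxy, or an amine or a carboxylic acid, would read at these places on either core.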